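This account rests on a few compounds, and the source may have more. Where it says the series, first, only, none or still open, it means among the compounds named here.

In a functional assay (strain AB) with Danio rerio as the target, read by microscopy, with a stated time of 1 h (on this read-out higher numbers stand for an effect only at larger amounts of compound and lower numbers for an effect already at smaller amounts), compound 1 (`CCN1CCc2c(sc(NC(=O)Nc3ccccc3)c2C(N)=O)C1`), with a bare phenyl on its urea, gives > 25000 nM, which is a limit of the assay and not a number. Within the data shown here, compound 2 (`CCN1CCc2c(sc(NC(=O)Nc3ccc(I)cc3)c2C(N)=O)C1`) gives 1620 nM, so far the only true number in this assay. The two differ by iodo in place of hydrogen on an aromatic carbon, and an at least 15-fold lower number from compound 1 to compound 2 (1.18 log units; beyond the scatter) is large and beyond the scatter.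

Compound 3 (`CCN1CCc2c(sc(NC(=O)Nc3ccc(Cl)cc3Cl)c2C(N)=O)C1`) keeps the shared core and has 2,4-dichlorophenyl in place of 4-iodophenyl on an amide-type nitrogen. Among the measured compounds shown here, only one measured step bears on this change. From it, an at least 15-fold lower number from compound 1 to compound 2 (1.18 log units; beyond the scatter) suggests that a substituted phenyl can matter in this assay, but it says nothing about exchanging iodine for chlorine. Compound 3 still carries a substituted phenyl, so it is expected to stay nearer to compound 2 than to the limit, though with wide uncertainty. The expected change, a 1.5-fold higher number from compound 2 to compound 3 (0.19 log units; within the scatter), is small and within the scatter, with no firm direction. For compound 3 the estimated value is 2500 nM, with an expected range from 600 nM to 12000 nM.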

Compound 3, half-maximal effective concentration: 11500 nM
For compound 3 the middle estimate is 4.6-fold (0.66 log units) below the measured one; low and high end bracket the measured number.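

Within this assay, it matters which substituted phenyl sits on this amide-type nitrogen, not only that the phenyl carries a substituent: exchanging 4-iodophenyl for 2,4-dichlorophenyl gives a 7.1-fold higher number from compound 2 to compound 3 (0.85 log units; beyond the scatter). Even so, the 2,4-dichlorophenyl group still reads better than the bare phenyl, with an at least 2.1-fold lower number from compound 1 to compound 3 (0.33 log units; beyond the scatter), so both substituted phenyl groups shown stand apart from the unsubstituted one. The size of that second step is only a bound, as the value of compound 1 is a limit of the assay and not a number: the limit of > 25000 nM in this assay, at which 1 of the 3 values shown sits.

The exchange from 4-iodophenyl to 2,4-dichlorophenyl changes the kind of halogen, the number of halogens and where they sit all at once, so the compounds shown cannot say which of these changes accounts for the higher number. A phenyl carrying a single chlorine would begin to pull these apart, and a phenyl carrying a methoxy or an amino group would show whether a halogen is needed on this ring at all.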